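From fluoro to chloro on the shared core

The compounds below may be only part of what the source reports. "The series", "measured", "known", "first", "only" and "open" are said of these compounds alone.

Measured so far in a functional assay on the whole organism for positive allosteric modulation, with Mus musculus as the target; a lower number here means that less compound is needed, a higher number that more compound is needed for the effect:
Compound 1 `CCC(=O)N(c1cccc(C)c1)C1CCCC1N(C)C` gives 3 mg/kg; 3 mg/kg (2 entries)
Compound 2 `CCC(=O)N(c1cccc(OC)c1)C1CCCC1N(C)C` gives 0.8 mg/kg
Compound 3 `CCC(=O)N(c1cccc(F)c1)C1CCCC1N(C)C` gives 0.4 mg/kg

Compound 3 (0.4 mg/kg) lies within the scatter of compound 2 (0.8 mg/kg), and its number is smaller than that of compound 1 (3 mg/kg; 3 mg/kg (2 entries)). Compound 4 `CCC(=O)N(c1cccc(Cl)c1)C1CCCC1N(C)C` has not yet been measured. It differs from compound 3 by chloro in place of fluoro on an aromatic carbon. Among the measured compounds shown here, the one measured step that bears on this change (a 2.0-fold lower number from compound 2 to compound 3 (0.30 log units; within the scatter)) involves fluoro and methoxy, and no measured compound carries chloro. The expected step in this assay (a 1.5-fold higher number from compound 3 to compound 4 (0.18 log units; within the scatter)) therefore stays within the scatter. For compound 4 the estimate is 0.6 mg/kg (expected range 0.2 mg/kg to 1.8 mg/kg).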

Compound 4, dose for half-maximal effect: 0.4 mg/kg
Beside the measured number, compound 4's estimate is 1.5-fold (0.18 log units) above it; measured number inside the range.
By their numbers in this assay, from the lowest: compounds 3, 4 and 2 (each within the scatter of the next).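

In this assay, chloro in place of fluoro on this aromatic carbon, meta to a large group, brings no change at the digits printed from compound 3 to compound 4 (within the scatter), so the two halogens cannot be told apart here. Chloro in place of methoxy gives a 2.0-fold lower number from compound 2 to compound 4 (0.30 log units; within the scatter), so neither halogen separates from methoxy either. Nothing measured here accounts for how these groups compare. On these data alone, whether a trifluoromethyl or an amine at this position would read alike remains open. So does whether chloro would behave the same way at another carbon of the ring.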